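The source may hold more compounds than are shown below. What is called first, only, known or untested is meant among the compounds shown, and "the series" means these compounds.

In an ADME assay on Huh-7 cells (Homo sapiens) for cytotoxicity, with a stated time of 72 h (a higher number here means that more compound is tolerated, a lower number that less compound is tolerated), compound 1 (`CC(C)CCn1nc(-c2cccs2)c(O)c(C2=CS(=O)(=O)c3cc(NS(C)(=O)=O)ccc3N2)c1=O`) gives > 1000 nM as a limit only. Compound 2 (`CS(=O)(=O)Nc1ccc2c(c1)S(=O)(=O)C=C(c1c(O)c(-c3cccs3)nn(CC3CCCC3)c1=O)N2`) gives > 1000 nM as a limit too. Within the data shown here, both stand at the limit of > 1000 nM in this assay, at which 2 of the 2 values shown sit, and the one measured step is a step that the two limits leave unreadable from compound 1 to compound 2 at a different group, so no size carries over. Compound 3 (`CC(C)CCn1nc(-c2ccccc2)c(O)c(C2=CS(=O)(=O)c3cc(NS(C)(=O)=O)ccc3N2)c1=O`) carries phenyl in place of thiophen-2-yl on an aromatic carbon. From compound 1 at > 1000 nM as a limit, no step beyond the scatter is expected in this assay for this change. The estimate for this change is a step that the limit leaves unreadable from compound 1 to compound 3 as an expected step. Compound 3 is estimated at 2000 nM within an expected range (600 nM to 10000 nM).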

Compound 3, half-maximal cytotoxic concentration: > 33000 nM
Compound 3 ended at the assay's limit; the forecaster's own chance of this, stated with the estimate: 75%; middle value at least 16-fold (1.21 log units) from the limit.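

In this assay compound 3 gives > 33000 nM, a limit only, so the step from compound 1 to compound 3 cannot be read. The compounds shown leave open the actual half-maximal cytotoxic concentration of each compound, and whether phenyl and thiophen-2-yl differ at all.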